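The source may report more compounds than this note shows. Statements on the series, on what has been measured and on what is new or still open speak of the compounds shown alone.

In an assay on membranes from uterus for displacement of a labelled ligand from Angiotensin type II receptor (Sus scrofa), with a stated time of 1.5 h (a lower number here means a stronger inhibitor, a higher number a weaker inhibitor), compound 1 `CCCCOC(=O)NS(=O)(=O)c1sc(CC(C)C)cc1-c1ccc(Cn2cccn2)cc1` gives 2.3 nM. For compound 2 `CCCCOC(=O)NS(=O)(=O)c1sc(CC(C)C)cc1-c1ccc(CN2C(=O)CCC2=O)cc1` this assay reports only a limit, > 10000 nM.

Compound 2 therefore stands at the edge of what this assay can read (the limit of > 10000 nM in this assay, at which 1 of the 2 values shown sits), with no number of its own. Compound 3 `CCCCOC(=O)NS(=O)(=O)c1sc(CC(C)C)cc1-c1ccc(Cn2ccc(C(F)(F)F)n2)cc1` differs from compound 2 by 3-(trifluoromethyl)-1H-pyrazol-1-yl in place of 2,5-dioxopyrrolidin-1-yl on a saturated chain carbon bound to an aromatic carbon. Within the data shown here, one measured step bears on this: an at least 4300-fold higher number from compound 1 to compound 2 (3.63 log units; beyond the scatter). Compound 3 carries a pyrazol-1-yl ring as compound 1 does, so the change is expected to run that step in reverse, giving a large fall in the number, an at least 2000-fold lower number from compound 2 to compound 3 (3.30 log units; beyond the scatter). Compound 3 is estimated at 5 nM, between 1 nM and 50 nM.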

Compound 3, inhibition constant: 9.5 nM
Compound 3: the middle estimate sits 1.9-fold (0.28 log units) below what was measured, and the stated range covers the measured number.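

In this assay, the pyrazol-1-yl ring on this saturated chain carbon still gives a low number when it carries a trifluoromethyl group, with an at least 1000-fold lower number from compound 2 to compound 3 (3.02 log units; beyond the scatter). Compound 2 has only a limit, so the size of that step is a minimum: the limit of > 10000 nM in this assay, at which 1 of the 3 values shown sits. Trifluoromethyl in place of hydrogen on an aromatic carbon of the ring does raise the number, with a 4.1-fold higher number from compound 1 to compound 3 (0.62 log units; beyond the scatter).

Going by these compounds, whether a methyl group or a chlorine atom on the ring would raise the number in the same way remains open. So does how an imidazole or triazole ring would compare with the pyrazole.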